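The compounds below may be only part of what the source reports. "The series", "measured", "known", "first", "only" and "open" are said of these compounds alone.

Compound 1 `NS(=O)(=O)c1cc(-c2nnc(CNC(=O)c3ccccc3)o2)c(Cl)cc1SCc1ccccc1` gives 42000 nM in a functional assay on HCT-116 cells (Homo sapiens) for cytotoxicity, read by MTT assay, with a stated time of 72 h; on this read-out higher numbers stand for weaker inhibition and lower numbers for stronger inhibition.
Compound 2 `NS(=O)(=O)c1cc(-c2nnc(/C=C/c3cccc(Cl)c3)o2)c(Cl)cc1SCc1ccccc1` gives 12000 nM in this assay.

Of the two numbers measured, compound 2 stands lowest in this assay, and its nearest neighbour is compound 1, separated by the step of a 3.5-fold lower number from compound 1 to compound 2 (0.54 log units; beyond the scatter). For the measured compounds named here, that single step swaps the whole group on an aromatic carbon of the shared core, and it is the only measured step available.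

Compound 3 `NS(=O)(=O)c1cc(-c2nnc(/C=C/c3c(Cl)cccc3Cl)o2)c(Cl)cc1SCc1ccccc1` keeps the ethenyl chain of compound 2 and changes only the ring at its end: 2,6-dichlorophenyl in place of 3-chlorophenyl on a double-bonded chain carbon bound to a double-bonded chain carbon. Going by the values given here, no measured step touches the pattern of chlorine on that ring, so the one step on record does not bear on this change; it shows only that the chain-bearing end of the molecule matters, without saying how a second chlorine will act.

With nothing pointing either way, the step from compound 2 to compound 3 in this assay is expected to stay within the scatter, estimated as no change at the digits printed from compound 2 to compound 3 (within the scatter). Compound 3 is therefore estimated to give 12000 nM, with a range from 4000 nM to 36000 nM.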

Compound 3, half-maximal inhibitory concentration: 32000 nM
Estimate against measurement, compound 3: 2.7-fold (0.43 log units) below, within the range that was stated.
By their numbers in this assay, from the lowest: compound 2; then compounds 3 and 1 (each within the scatter of the next).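

In this assay the ring at the end of the chain now proves to count on its own: with the ethenyl chain kept, 2,6-dichlorophenyl in place of 3-chlorophenyl gives a 2.7-fold higher number from compound 2 to compound 3 (0.43 log units; beyond the scatter) on this position. The earlier step swapped the whole group at once, and the new comparison with benzamidomethyl, a 1.3-fold lower number from compound 1 to compound 3 (0.12 log units; within the scatter), shows that an ethenyl chain in that place does not by itself set a compound apart from compound 1, so the step away from compound 1 depends on which ring the chain carries. Nothing measured here gives a reason for the difference between the two rings.

The compounds shown leave open whether the number of chlorines or their places on the ring decides the result, as 2,6-dichlorophenyl changes both at once compared with 3-chlorophenyl. They also leave open how this assay would read for a ring carrying an amine or a carboxylic acid, or for a longer chain in place of the ethenyl link.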